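Swapping the chain end of a uracil alkyne for chlorine

The source may report more compounds than this note shows. Statements on the series, on what has been measured and on what is new or still open speak of the compounds shown alone.

Measured in a functional assay on HeLa cells (Homo sapiens) for antiproliferative activity, read by MTT assay, with a stated time of 72 h (a lower number here means a stronger inhibitor, a higher number a weaker inhibitor), so far:
- compound 1 `O=c1[nH]c(=O)n(CCC(CO)CO)cc1C#Cc1cc(F)cc(F)c1` gives 31200 nM
- compound 2 `O=c1[nH]c(=O)n(CCC(CO)CO)cc1C#CCc1ccccc1` gives 63800 nM
- compound 3 `CCCCCC#Cc1cn(CCC(CO)CO)c(=O)[nH]c1=O` gives 76300 nM

All three share the same core and the same diol-bearing side chain; they differ only in what hangs from the triple bond. Among the compounds with values here, compound 3 shows the highest number of the three, although its difference from compound 2 is within the usual scatter, so the two cannot be ranked against each other; only the step of a 2.4-fold higher number from compound 1 to compound 3 (0.39 log units; beyond the scatter) is beyond the scatter and modest.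

Compound 4 `O=c1[nH]c(=O)n(CCC(CO)CO)cc1C#CCCCCl` is not yet measured. The change from compound 3 is chloro in place of ethyl on a saturated chain carbon, three bonds along the chain from a triple-bonded carbon, so the chain is shortened and capped with chlorine. Within the data shown here, the closest precedent is the step of a 1.2-fold higher number from compound 2 to compound 3 (0.08 log units; within the scatter), a swap at the same kind of chain carbon that did not move the number beyond the scatter, while a 2.4-fold higher number from compound 1 to compound 3 (0.39 log units; beyond the scatter) was modest. A change at the far end of the chain is therefore expected to matter little, and compound 4 is estimated near compound 3 in this assay, with an expected step of a 1.1-fold lower number from compound 3 to compound 4 (0.04 log units; within the scatter), within the scatter. Compound 4 is expected at about 70000 nM, in the range 30000 nM to 160000 nM.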

Compound 4, half-maximal inhibitory concentration: > 100000 nM
Compound 4 gave a limit, no number; the forecaster's own chance of this, stated with the estimate: 15%; at least 1.4-fold (0.15 log units) between middle value and limit.
By their numbers in this assay, from the lowest: compound 1; then compounds 2 and 3 (each within the scatter of the next). At a limit, above all of these: compound 4.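

In this assay compound 4 gives a limit of the assay rather than a number: the limit of > 100000 nM in this assay, at which 1 of the 4 values shown sits. Because this is a limit, each step to it is only a floor: an at least 1.3-fold higher number from compound 3 to compound 4 (0.11 log units; that floor lies within the scatter) and an at least 1.5-fold higher number from compound 2 to compound 4 (0.19 log units; that floor lies within the scatter) leave open whether the true gaps exceed the usual scatter, whereas an at least 3.2-fold higher number from compound 1 to compound 4 (0.50 log units; beyond the scatter) is a real separation. So chloro in place of ethyl at this chain carbon gives no sign of stronger activity, and among these four compounds the 3,5-difluorophenyl group of compound 1 still gives the lowest number.

As far as these compounds go, the true value of compound 4 remains unknown, so the effect of this change cannot yet be sized. From the compounds shown here alone, it is also open whether an amine or a carboxylic acid in place of the chlorine, or a longer chain ending in chlorine, would lower the number.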